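One more methoxy on compound 1: what to expect

The source may report more compounds than this note shows. Statements on the series, on what has been measured and on what is new or still open speak of the compounds shown alone.

Measured so far in a functional assay on 786-0 cells (Homo sapiens) for inhibition, read by sulforhodamine B assay, with a stated time of 48 h (on this read-out lower numbers stand for stronger inhibition of growth and higher numbers for weaker inhibition of growth), are two compounds:
- Compound 1 `COc1ccc(/C=C/C2(C)C=CC(=O)O2)c(OC)c1` gives 108000 nM
- Compound 2 `COc1cc(OC)c(OC)cc1/C=C/C1(C)C=CC(=O)O1` gives 205000 nM

Within the data shown here, compound 1 has only one neighbour on these numbers, and the two cannot be told apart: the gap is a 1.9-fold higher number from compound 1 to compound 2 (0.28 log units; within the scatter) and so does not show a real difference. The compound still to be measured is compound 3 `COc1cc(OC)c(/C=C/C2(C)C=CC(=O)O2)c(OC)c1`. It differs from compound 1 by one change: methoxy in place of hydrogen on an aromatic carbon on the ring that already carries two methoxy groups.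

Compound 2 also differs from compound 1 by methoxy in place of hydrogen on an aromatic carbon, though at another place on that ring. Among the measured compounds shown here, that single step of a 1.9-fold higher number from compound 1 to compound 2 (0.28 log units; within the scatter) is the only guide available, and no measured compound yet carries the new group at the place it occupies in compound 3. A step beyond the scatter is therefore not expected in this assay and any drift would most likely lean towards a higher number. The estimate amounts to a 1.3-fold higher number from compound 1 to compound 3 (0.11 log units; within the scatter) as the expected step. For compound 3 the estimated value is 140000 nM with an expected range from 65000 nM to 300000 nM on this read-out.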

Compound 3, concentration for total growth inhibition: 459000 nM
Estimate against measurement, compound 3: 3.3-fold (0.52 log units) below, and the stated range ends below it.
By their numbers in this assay, from the lowest: compounds 1 and 2 (each within the scatter of the next); then compound 3.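

In this assay, among these compounds, methoxy in place of hydrogen on the aromatic carbon ortho to a group of 9 heavy atoms and meta to two methoxy groups gives the first step here that lies beyond the scatter (a 4.3-fold higher number from compound 1 to compound 3 (0.63 log units; beyond the scatter)). The same kind of change at another place on the ring gave no real difference (a 1.9-fold higher number from compound 1 to compound 2 (0.28 log units; within the scatter)), so the outcome of adding a methoxy depends on where it sits on this ring, and at this position it goes with weaker inhibition of growth. No measured evidence is available on what lies behind this step.

The compounds shown leave open whether the step belongs to methoxy itself or to any substituent at this position, a question that a hydroxyl group, a fluorine atom or an amine there could help to answer. They also leave open whether the step depends on the two methoxy groups already on the ring, and whether a methoxy at this position would give a similar step on a ring carrying neither of them.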